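Tosylation of an Inactive Triazole Series Against Breast Cancer Cells

The source may hold more compounds than are shown below. What is called first, only, known or untested is meant among the compounds shown, and "the series" means these compounds.

The measured compounds:
Compound 1 `Cc1c(O)ccc2c1[C@H](Cn1cc(-c3ccccc3)nn1)[C@@]13CC(=O)[C@@](C)(CC[C@@H]21)C3`: in a functional assay on MCF7 cells (Homo sapiens) for cytotoxicity, read by MTT assay, with a stated time of 4 days (a higher number here means a weaker inhibitor, a lower number a stronger inhibitor), compound 1 gives > 20000 nM, a limit of the assay.
Compound 2 `Cc1ccc(S(=O)(=O)Oc2ccc3c(c2C)[C@H](Cn2cc(-c4ccccc4)nn2)[C@@]24CC(=O)[C@@](C)(CC[C@@H]32)C4)cc1`: in this assay compound 2 gives > 20000 nM, also a limit.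
Compound 3 `Cc1c(O)ccc2c1[C@H](Cn1cc(-c3ccc(Cl)cc3)nn1)[C@@]13CC(=O)[C@@](C)(CC[C@@H]21)C3`: in this assay compound 3 gives > 20000 nM, again a limit.

For the measured compounds named here, all three values sit at the limit of > 20000 nM in this assay, at which 3 of the 3 values shown sit, so no compound among them can be called stronger or weaker than another. The change from compound 1 to compound 2 is (4-methylphenyl)sulfonyl in place of hydrogen on an oxygen on an aromatic ring, and the step it made, a step that the two limits leave unreadable from compound 1 to compound 2, cannot be read, since both ends are limits. The cores of compound 1 and compound 3 differ by chloro in place of hydrogen on an aromatic carbon; the step that the two limits leave unreadable from compound 1 to compound 3 is likewise unreadable.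

Compound 4 `Cc1ccc(S(=O)(=O)Oc2ccc3c(c2C)[C@H](Cn2cc(-c4ccc(Cl)cc4)nn2)[C@@]24CC(=O)[C@@](C)(CC[C@@H]32)C4)cc1` is not yet measured. It differs from compound 3 by (4-methylphenyl)sulfonyl in place of hydrogen on an oxygen on an aromatic ring, the same change that turned compound 1 into compound 2, with the place described in the same words. Since compound 3 gives only > 20000 nM in this assay, and compound 2 likewise stayed at the limit after the same change, compound 4 is expected to remain at the limit too, and the step that the limit leaves unreadable from compound 3 to compound 4 is estimated to be unreadable as well. The estimate for compound 4 is 30000 nM.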

Compound 4, half-maximal inhibitory concentration: > 20000 nM
Compound 4: no number, only a limit; the forecaster's own chance of this, stated with the estimate: 85%; the middle value is on the limit's open side.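

In this assay compound 4 gives > 20000 nM, a limit of the assay. The steps from compound 3 to compound 4 and from compound 2 to compound 4 therefore cannot be read: the limit of > 20000 nM in this assay, at which 4 of the 4 values shown sit. The compounds shown leave open whether (4-methylphenyl)sulfonyl or chloro in place of hydrogen changes potency at all in this assay.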